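This account rests on a few compounds, and the source may have more. Where it says the series, first, only, none or still open, it means among the compounds named here.

Compound 1, `Cc1nc2c3ccccc3ccc2c2nc3c(ccc4ccccc43)c(-c3cccc([N+](=O)[O-])c3)c12`, gives 157 ug/mL in a functional assay, with a stated time of 90 s; a higher number here means a weaker inhibitor, a lower number a stronger inhibitor.
Compound 2, `COc1ccc(-c2c3ccc4ccccc4c3nc3c2c(C)nc2c4ccccc4ccc32)cc1`, gives 176 ug/mL in this assay.
Compound 3, `Cc1nc2c3ccccc3ccc2c2nc3c(ccc4ccccc43)c(-c3cccc4ccccc34)c12`, gives 179 ug/mL in this assay.

The three measured compounds share one core and differ only in the aryl group carried on an aromatic carbon of that core. In this assay compound 1 has the lowest of the three numbers, yet its distance to the other two is small: a 1.1-fold higher number from compound 1 to compound 2 (0.05 log units; within the scatter), and a 1.1-fold higher number from compound 1 to compound 3 (0.06 log units; within the scatter). The remaining pair behaves the same way, with a 1.0-fold higher number from compound 2 to compound 3 (0.01 log units; within the scatter). Nothing among these three separates one aryl group from another beyond the usual scatter.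

Compound 4, `Cc1nc2c3ccccc3ccc2c2nc3c(ccc4ccccc43)c(-c3ccccc3N)c12`, has not yet been measured. It differs from compound 1 in one place: 2-aminophenyl in place of 3-nitrophenyl on an aromatic carbon. Within the data shown here, the steps that bear on this change are those from compound 1 to compound 2 and from compound 1 to compound 3, both of which also replace 3-nitrophenyl at the same aromatic carbon and both of which stay within the scatter. On that basis compound 4 is expected to give a step within the scatter in this assay, in no particular direction, so a 1.1-fold higher number from compound 1 to compound 4 (0.02 log units; within the scatter). The estimate for compound 4 in this assay is 165 ug/mL, with a range from 90 ug/mL to 300 ug/mL.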

Compound 4, half-maximal inhibitory concentration: 125 ug/mL
Compound 4: middle estimate off by 1.3-fold (0.12 log units), on the high side; measured number inside the range.
By their numbers in this assay, from the lowest: compounds 4, 1, 2 and 3 (each within the scatter of the next).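

In this assay, the change gives a 1.3-fold lower number from compound 1 to compound 4 (0.10 log units; within the scatter), so at this aromatic carbon, opposite the ring nitrogen, a group with a hydrogen-bond donor and fewer heavy atoms than 3-nitrophenyl still does not move the number beyond the scatter. The comparisons with the other two aryl groups read the same way, with a 1.4-fold lower number from compound 3 to compound 4 (0.16 log units; within the scatter) and a 1.4-fold lower number from compound 2 to compound 4 (0.15 log units; within the scatter), so these are the largest steps seen so far at this position, yet 2-aminophenyl still cannot be separated from 3-nitrophenyl, 4-methoxyphenyl or naphthalen-1-yl. The data shown offer no evidence on why these changes of aryl group leave the number within the scatter.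

The compounds shown leave open whether any group at this carbon can produce a step beyond the scatter, for instance a phenyl ring carrying a carboxylic acid, or a longer alkyl chain in place of the aryl ring. They also leave open whether the place of the amine on the phenyl ring matters, as 3-aminophenyl and 4-aminophenyl would show, and whether an acetamide in place of the free amine would read any differently.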